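The source may report more compounds than this note shows. Statements on the series, on what has been measured and on what is new or still open speak of the compounds shown alone.

Compound 2 `Cc1ccc(C(=O)NNC(=O)c2cc(I)cc(I)c2O)cc1` and compound 1 `O=C(N/N=C/c1cc(I)c(O)c(I)c1)c1ccc(O)cc1` share a core carrying two iodine atoms and have both been tested in a functional assay on HepG2 cells (Homo sapiens) for cytotoxicity, with a stated time of 24 h; a higher number here means a weaker inhibitor, a lower number a stronger inhibitor. Compound 2 gives 86400 nM and compound 1 gives 110000 nM; the two numbers lie within the usual scatter of each other, so neither can be set apart from the other. Compound 3 `O=C(NNC(=O)c1cc(I)cc(I)c1O)c1ccc(F)cc1` has not been measured. It differs from compound 2 by fluoro in place of methyl on an aromatic carbon. Going by the values given here, no measured pair shows this change, so no step beyond the scatter is expected in this assay in either direction. Compound 3 is therefore expected to give 90000 nM, within 40000 nM to 200000 nM, an expected step of a 1.0-fold higher number from compound 2 to compound 3 (0.02 log units; within the scatter).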

Compound 3, half-maximal inhibitory concentration: 87000 nM
For compound 3 the middle estimate is 1.0-fold (0.01 log units) above the measured one; measured number inside the range.
By their numbers in this assay, from the lowest: compounds 2, 3 and 1 (each within the scatter of the next).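

Going by these compounds alone, the swap of 4-methylphenyl to 4-fluorophenyl is the first change in a single place that can be read in this assay, and it gives a 1.0-fold higher number from compound 2 to compound 3 (0.00 log units; within the scatter) within the scatter. At this position on the aromatic ring, para to a large group, methyl and fluoro therefore cannot be told apart in this measurement. No measured information here offers a reason for this result. Still open, from the compounds shown here alone, is whether an amine, a carboxylic acid or a longer chain at this position would shift the number beyond the scatter.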